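A few compounds are considered here, and "the series" means these few. Any claim that something is new, unique, unknown or untested is made for them only; others in the source may bear on it.

Measured compounds:
- compound 1, `O=c1cc(-c2ccccc2)oc2c(OCCCN3CCCC3)c(OCc3ccccc3)cc(O)c12`: 7980 nM
- compound 2, `CN1CCN(CCCCOc2c(OCc3ccc(C#N)cc3)cc(O)c3c(=O)cc(-c4ccccc4)oc23)CC1`: 3700 nM

Of the compounds shown here, two sharing the same core have been tested in a functional assay on B16 cells (Mus musculus) for cytotoxicity, read by MTT assay, with a stated time of 72 h; a higher number here means a weaker inhibitor, a lower number a stronger inhibitor. Compound 1 gives 7980 nM in this assay, and compound 2 gives 3700 nM. Compound 2 therefore stands at the lowest number of the two, with compound 1 the nearest at a higher number, a gap that lies beyond the scatter of repeated measurements. The two differ in more than one place, so no single change can be tied to that gap.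

Compound 3, `CN1CCN(CCCCOc2c(OCc3nc4ccccc4s3)cc(O)c3c(=O)cc(-c4ccccc4)oc23)CC1`, has not yet been measured in this assay. It differs from compound 2 in one place: 1,3-benzothiazol-2-yl in place of 4-cyanophenyl on a saturated chain carbon bound to an oxygen on an aromatic ring. Among the measured compounds shown here, no measured pair shows this kind of exchange, so there is nothing in the data that points to a direction. The step from compound 2 to compound 3 is expected to be small, a 1.1-fold lower number from compound 2 to compound 3 (0.02 log units; within the scatter), and not beyond the usual scatter. For compound 3 the value in this assay is estimated at 3500 nM, with a range from 1500 nM to 9000 nM.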

Compound 3, half-maximal inhibitory concentration: 2780 nM
For compound 3 the middle estimate is 1.3-fold (0.10 log units) above the measured one; low and high end bracket the measured number.
By their numbers in this assay, from the lowest: compounds 3 and 2 (each within the scatter of the next); then compound 1.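

Among the compounds shown here, the exchange of 4-cyanophenyl for 1,3-benzothiazol-2-yl on a saturated chain carbon bound to an oxygen on an aromatic ring is the first change in one place that can be read in this set, and in this assay it gives a 1.3-fold lower number from compound 2 to compound 3 (0.12 log units; within the scatter). At this position, then, the fused pair of aromatic rings with its sulfur and ring nitrogen and the single carbon-only aromatic ring with its nitrile are not told apart by this read-out, even though the two groups share little beyond their aromatic character. Nothing in the available data bears on why the two groups read alike.

Compound 1 differs from compound 2 and compound 3 in more than one place, so its higher number cannot be tied to this exchange or to any other single change. The compounds shown leave open whether a carboxylic acid or an amine in place of the nitrile, or a longer chain between the oxygen on the aromatic ring and the 4-cyanophenyl group, would move the number beyond the scatter.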